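Trimming the triazole chain on a diaryl ether urea hydrazone

This account rests on a few compounds, and the source may have more. Where it says the series, first, only, none or still open, it means among the compounds named here.

Of the compounds shown here, three sharing one core have been tested in a functional assay on A549 cells (Homo sapiens) for cytotoxicity, read by MTT assay, with a stated time of 72 h; a lower number here means a stronger inhibitor, a higher number a weaker inhibitor. Compound 1 `COc1ccc(/C=N/NC(=O)Nc2ccc(Oc3ccnc(-c4nncn4CCN(C)C)c3)c(F)c2)c(OC)c1OC` gives 6680 nM. Compound 2 `CN(C)CCn1cnnc1-c1cc(Oc2ccc(NC(=O)N/N=C/c3ccccc3)cc2F)ccn1` gives 1860 nM, the lowest of the two numbers shown, and the step of a 3.6-fold lower number from compound 1 to compound 2 (0.56 log units; beyond the scatter) is beyond the scatter. Compound 3 `COc1ccc(/C=N/NC(=O)Nc2ccc(Oc3ccnc(-c4nncn4CCN(C)C)c3)c(F)c2)cc1O` reaches only the limit of the assay, > 100000 nM, so its value is a limit and not a number. Both measured steps, an at least 14-fold higher number from compound 1 to compound 3 (1.17 log units; beyond the scatter) and an at least 53-fold higher number from compound 2 to compound 3 (1.73 log units; beyond the scatter), concern the ring on the carbon with a double bond to nitrogen; none of them touches the chain on the triazole.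

Compound 4 `Cn1cnnc1-c1cc(Oc2ccc(NC(=O)N/N=C/c3ccccc3)cc2F)ccn1` differs from compound 2 by hydrogen in place of (dimethylamino)methyl on a saturated chain carbon bound to an aromatic nitrogen, which cut one bond further out reads 2-(dimethylamino)ethyl to methyl. Among the compounds with values here, no measured step bears directly on this change, so no strong shift is expected. For compound 4 the step is estimated as a 1.6-fold higher number from compound 2 to compound 4 (0.21 log units; within the scatter), about at the edge of the scatter. In this assay compound 4 is therefore expected to give roughly 3000 nM, within 900 nM to 10000 nM.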

Compound 4, half-maximal inhibitory concentration: 7560 nM
The estimate for compound 4 lay 2.5-fold (0.40 log units) below the measured number; the measured number falls inside the stated range.
By their numbers in this assay, from the lowest: compound 2; then compounds 1 and 4 (each within the scatter of the next). At a limit, above all of these: compound 3.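

Until now every step concerned the ring on the carbon with a double bond to nitrogen, but here the change sits on the triazole: in this assay, replacing 2-(dimethylamino)ethyl with methyl while keeping the phenyl brings a 4.1-fold higher number from compound 2 to compound 4 (0.61 log units; beyond the scatter) and so a weaker inhibitor. The chain is therefore not a silent position, although the step is only modest. Nothing measured here explains the shift.

The compounds shown cannot separate the role of the chain's length from that of its nitrogen, and a plain ethyl chain or a longer chain ending in a dimethylamino group would address that question. On these data alone, it also remains open whether the same step would appear with the 2,3,4-trimethoxyphenyl of compound 1 in place of the phenyl.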